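Taking the carbamoyl group off compound 1

A few compounds are considered here, and "the series" means these few. Any claim that something is new, unique, unknown or untested is made for them only; others in the source may bear on it.

Liver preparations show how quickly a compound is broken down, which makes them an early check on whether it would last in the body. In an in vitro ADME assay on S9 fraction from liver (Rattus norvegicus, strain Wistar) for metabolic stability, read by HPLC, tested at 1 uM (a higher number here means that the compound lasts longer, a lower number that the compound disappears faster), compound 1 `NC(=O)c1cccc(-c2cccc(OC(=O)NCCCCc3ccccc3)c2)c1` gives 0.782 h and compound 2 `O=C(NCc1ccc2ccccc2c1)Oc1cccc(-c2ccccc2)c1` gives 0.458 h. These two numbers lie within the usual scatter of each other, so neither compound can be said to last longer.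

Compound 3 `O=C(NCCCCc1ccccc1)Oc1cccc(-c2ccccc2)c1` differs from compound 1 in one place: hydrogen sits in place of carbamoyl on an aromatic carbon, so 3-carbamoylphenyl becomes phenyl (hydrogen in place of carbamoyl on an aromatic carbon). Going by the values given here, no measured pair of compounds shows this change on its own, so any forecast is loose. Among the compounds with values here, the only guide is that both half-lives measured so far are close together, with compound 2 at 0.458 h as the lower number. A modest shortening is therefore the working guess, and it may well not exceed the scatter. The estimated 1.6-fold lower number from compound 1 to compound 3 (0.19 log units; within the scatter) is small and points downward. For compound 3 the expected half-life in this assay is 0.5 h, with an estimated range from 0.22 h to 1.1 h.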

Compound 3, half-life in the liver assay: 0.322 h
Compound 3: middle estimate off by 1.6-fold (0.19 log units), on the high side; measured number inside the range.
By their numbers in the liver assay, from the lowest: compounds 3, 2 and 1 (each within the scatter of the next, the first and the last beyond it).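

Going by these compounds alone, this is the first pair that isolates a single change, and in the liver assay replacing carbamoyl with hydrogen on an aromatic carbon gives a 2.4-fold lower number from compound 1 to compound 3 (0.39 log units; beyond the scatter). In the liver assay compound 1 gives 0.782 h and compound 3 gives 0.322 h. The group at this position therefore matters modestly for how long the compound lasts in the liver preparation, with the carbamoyl compound lasting longer. In a physicochemical assay for pharmacokinetics, read by HPLC, at pH 9.0 (a lower number here means that the compound disappears faster, a higher number that the compound lasts longer), compound 1 gives 0.505 h and compound 3 gives 0.713 h. In the physicochemical assay, the same change gives a 1.4-fold higher number from compound 1 to compound 3 (0.15 log units; within the scatter), so no shift can be claimed in that test, and the difference between these two compounds appears only in the liver assay.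

Nothing available explains why removing carbamoyl makes this difference in one test and not in the other.

Going by these compounds, it remains open whether other groups at this position, such as an amine, a carboxylic acid or a methoxy group, would match carbamoyl or differ from it in the liver assay, and whether the same exchange of carbamoyl for hydrogen would give a similar step on a compound carrying the side chain of compound 2.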